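The compounds below may be only part of what the source reports. "The series", "measured", "known", "first", "only" and "open" are said of these compounds alone.

Compound 3, whose structure is `O=c1[nH]c2ccccc2cc1/C=N/Nc1ccccc1`, stands lowest of the three numbers measured in a functional assay, read by spectrophotometry, with a stated time of 30 min; a lower number here means a stronger inhibitor, a higher number a weaker inhibitor; compound 3 gives 76500 nM. Its nearest neighbour is compound 1, with structure `N/N=C/c1cc2ccccc2[nH]c1=O`, which gives 729000 nM in this assay, and its furthest is compound 2, with structure `NS(=O)(=O)CC(=O)N/N=C/c1cc2ccccc2[nH]c1=O`, which gives 1290000 nM. The step of a 9.5-fold lower number from compound 1 to compound 3 (0.98 log units; beyond the scatter) and the step of a 17-fold lower number from compound 2 to compound 3 (1.23 log units; beyond the scatter) both come from replacing the group on the amine nitrogen, while the step of a 1.8-fold higher number from compound 1 to compound 2 (0.25 log units; within the scatter) stays within the scatter.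

Compound 4, with structure `O=c1[nH]c2ccccc2cc1/C=N/Nc1ccc([N+](=O)[O-])cc1`, differs from compound 3 by nitro in place of hydrogen on an aromatic carbon. For the measured compounds named here, none of the measured steps touches the phenyl ring itself: every one of them changes what sits on the amine nitrogen, so no measured step bears directly on this change. Going by the values given here, the only guidance is that compound 3 already carries the phenyl that gives the lowest number here, and the change leaves that phenyl in place. Compound 4 is therefore expected to give a number close to that of compound 3, with a step of a 1.3-fold lower number from compound 3 to compound 4 (0.11 log units; within the scatter) that may fall within the scatter. The estimate for compound 4 in this assay is 60000 nM, within a range from 20000 nM to 200000 nM.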

Compound 4, half-maximal inhibitory concentration: 170000 nM
Beside the measured number, compound 4's estimate is 2.8-fold (0.45 log units) below it, within the range that was stated.
By their numbers in this assay, from the lowest: compound 3; then compound 4; then compounds 1 and 2 (each within the scatter of the next).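

For the compounds shown here, compound 4 is the first compound here in which the change falls on the phenyl ring rather than on the group attached to the amine nitrogen, and in this assay nitro in place of hydrogen on an aromatic carbon, para to a large group, gives a 2.2-fold higher number from compound 3 to compound 4 (0.35 log units; beyond the scatter) as its step. This shows that the number responds to a change at this ring position: the step is modest but beyond the scatter, and it runs upward, so the lower number of compound 3 does not persist unchanged once nitro enters at this place. No evidence is available on why nitro has this effect.

Going by these compounds, a single group at a single position cannot show whether the upward step belongs to nitro or to any group placed there, so it remains open how an amine, a methoxy group, a chlorine atom or a carboxylic acid at the same place would compare with compound 3. On these data alone, it also remains open whether nitro on another carbon of the phenyl ring would give a step of the same direction and size.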